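The source may hold more compounds than are shown below. What is called first, only, known or untested is meant among the compounds shown, and "the series" means these compounds.

Measured so far in a functional assay on KG-1 cells (Homo sapiens) for antiproliferative activity, read by CCK-8 assay, with a stated time of 72 h; a higher number here means a weaker inhibitor, a lower number a stronger inhibitor
- compound 1 `Cc1ccc(C(=O)Nc2cccc(C(F)(F)F)c2)cc1-c1ccc2c(-c3ccc(C(=O)N4CCN(C)CC4)cc3)n[nH]c2c1` gives 300 nM
- compound 2 `Cc1ccc(C(=O)Nc2cccc(C(F)(F)F)c2)cc1-c1ccc2c(-c3ccc(CN4CCN(C)CC4)cc3)n[nH]c2c1` gives 120 nM
- compound 3 `Cc1ccc(C(=O)Nc2cccc(C(F)(F)F)c2)cc1-c1ccc2c(-c3cnn(C)c3)n[nH]c2c1` gives 65.7 nM

Compound 3 and compound 2 lie within the scatter of each other in this assay while compound 1 carries a higher number than compound 3, with the gap beyond the scatter.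

Compound 4 `Cc1ccc(C(=O)Nc2cccc(C(F)(F)F)c2)cc1-c1ccc2c(-c3cnn(C4CC4)c3)n[nH]c2c1` has cyclopropyl in place of methyl on an aromatic nitrogen and so reads 1-methyl-1H-pyrazol-4-yl to 1-cyclopropyl-1H-pyrazol-4-yl. Among the compounds with values here, no measured step changes the group on this nitrogen. Within the data shown here, the one measured step of a 2.5-fold lower number from compound 1 to compound 2 (0.40 log units; beyond the scatter) is modest and swaps (4-methylpiperazin-1-yl)carbonyl for (4-methylpiperazin-1-yl)methyl on an aromatic carbon, so it bears on this change only loosely. With nothing pointing either way, no step beyond the scatter is expected in this assay. Compound 3 at 65.7 nM remains the anchor. The expected size is a 1.1-fold lower number from compound 3 to compound 4 (0.04 log units; within the scatter) and that lies within the scatter. Compound 4 is estimated at 60 nM with 25 nM to 150 nM as the expected range.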

Compound 4, half-maximal inhibitory concentration: 108 nM
Compound 4: middle estimate off by 1.8-fold (0.26 log units), on the low side; the measured number falls inside the stated range.
By their numbers in this assay, from the lowest: compounds 3, 4 and 2 (each within the scatter of the next); then compound 1.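

In this assay, this pair is the only one shown that changes the group on the aromatic nitrogen of the five-membered aromatic ring, and the step reads a 1.6-fold higher number from compound 3 to compound 4 (0.22 log units; within the scatter). Replacing methyl with cyclopropyl adds two carbons and a three-membered ring at this position, yet the step stays within the scatter, so this one pair gives no sign that the position separates these two groups. No measurement on hand offers an explanation for this result.

As far as these compounds go, it remains open whether an ethyl or isopropyl group, a longer chain ending in an amine or a hydroxyl, or a plain hydrogen on this nitrogen would also stay within the scatter of compound 3. Also open, from the compounds shown here alone, is whether the same reading would hold with a nitrile in place of the trifluoromethyl group on the shared core.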